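Ethylamino in place of propyl on the thiocarbonyl carbon

The compounds below may be only part of what the source reports. "The series", "measured", "known", "first", "only" and "open" are said of these compounds alone.

Within the data shown here, compound 2 `CCCC(=S)SCC(=O)c1ccc(OC)cc1` holds the lowest of the two numbers known in an assay on HEK293 cells for inhibition of protein deacetylase HDAC6 (Homo sapiens) (a lower number here means a stronger inhibitor, a higher number a weaker inhibitor), giving 110 nM. Compound 1 `COCCSC(=S)SCC(=O)c1ccc(OC)cc1` gives 2130 nM in this assay, and the change a 19-fold lower number from compound 1 to compound 2 (1.29 log units; beyond the scatter) shows how strongly the group on the thiocarbonyl carbon sets the number. Compound 3 `CCNC(=S)SCC(=O)c1ccc(OC)cc1` carries ethylamino in place of propyl on a thiocarbonyl carbon. Among the measured compounds shown here, no measured step covers this exchange; the only step at this place was large. A moderate rise is therefore expected, a 3.6-fold higher number from compound 2 to compound 3 (0.56 log units; beyond the scatter), and compound 3 is estimated at 400 nM, within 100 nM to 1600 nM.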

Compound 3, half-maximal inhibitory concentration: 94 nM
The estimate for compound 3 lay 4.3-fold (0.63 log units) above the measured number; the whole stated range lies above it.
By their numbers in this assay, from the lowest: compounds 3 and 2 (each within the scatter of the next); then compound 1.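

In this assay, ethylamino on the thiocarbonyl carbon gives a result that cannot be told apart from that with propyl (a 1.2-fold lower number from compound 2 to compound 3 (0.07 log units; within the scatter)), so a nitrogen-linked chain and a carbon-linked chain are equivalent here. Ethylamino also stands well clear of (2-methoxyethyl)sulfanyl (a 23-fold lower number from compound 1 to compound 3 (1.36 log units; beyond the scatter)), so the large earlier step is not particular to propyl. No evidence is available that accounts for these results. The compounds shown leave open how dimethylamino, which has no hydrogen on its nitrogen, or a longer chain such as butylamino would read on this thiocarbonyl carbon.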